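Cyclohexyl to phenyl at the ring nitrogen: an untested step

The source may report more compounds than this note shows. Statements on the series, on what has been measured and on what is new or still open speak of the compounds shown alone.

Three compounds of the series have been run in an assay for inhibition of acid-sensing ion channel 3 (Homo sapiens), read by patch clamp, tested at 1 uM; on this read-out lower numbers stand for less inhibition and higher numbers for more inhibition at the one concentration tested (going by the name of the read-out). Compound 1 `NC(N)=NC(=O)c1nc(Cl)c(NCc2ccc3ccccc3c2)nc1N` gives 27%, compound 2 `NC(N)=NC(=O)c1nc(Cl)c(NC2CCCCC2)nc1N` gives 21%, and compound 3 `NC(N)=NC(=O)c1nc(Cl)c(N2CCc3ccccc32)nc1N` gives 46%. On these numbers compound 2 sits at the bottom end, but its gap to compound 1 lies within the scatter of repeated measurements, so the two cannot be told apart; only compound 3 stands clearly higher than compound 2, by a margin beyond the scatter.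

Compound 4 `NC(N)=NC(=O)c1nc(Cl)c(Nc2ccccc2)nc1N` has not been measured. It differs from compound 2 in a single place: phenyl in place of cyclohexyl on a nitrogen on an aromatic ring. Among the compounds with values here, no pair of measured compounds differing in one place is available, so nothing directly calibrates what a cyclohexyl to phenyl exchange on this nitrogen does in this assay.

Given that, the expectation for compound 4 is a step from compound 2 that is small, most likely within the scatter, with any drift rather upward than downward, estimated as a number 9 percentage points higher from compound 2 to compound 4 (within the scatter). Compound 4 is accordingly expected to give about 30% in this assay, with a plausible range from 15% to 48%.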

Compound 4, a percentage reported as inhibition, at one concentration (the size of the read-out at that concentration, not a potency): 44%
For compound 4 the middle estimate is 14 percentage points below the measured one; the measured number falls inside the stated range.
By their numbers in this assay, from the lowest: compounds 2 and 1 (each within the scatter of the next); then compounds 4 and 3 (each within the scatter of the next).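

In this assay, within the data shown here, phenyl in place of cyclohexyl on a nitrogen on an aromatic ring gives a number 23 percentage points higher from compound 2 to compound 4 (beyond the scatter) and so provides the first single-place step, showing that the read-out responds to the group at this position. The two groups match in what is counted: each has six carbon heavy atoms in a six-membered ring, with no hydrogen-bond donors, no hydrogen-bond acceptors and no net charge, so the computed difference between them is that the ring is aromatic in compound 4 and non-aromatic in compound 2. Nothing measured here accounts for the step, and its origin stays unassigned.

The compounds shown leave open whether the step is specific to phenyl or would also appear with a pyridyl ring, or with a phenyl ring carrying a methoxy group, a chlorine or a carboxylic acid. As this is a single step read at one concentration, they also leave open how it would translate into potency in this assay and whether it would hold with a different group elsewhere on the shared core.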